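The source may report more compounds than this note shows. Statements on the series, on what has been measured and on what is new or still open speak of the compounds shown alone.

Measured so far, in an ADME assay on HEK293 cells (Homo sapiens) for cytotoxicity, read by ATP content, with a stated time of 6 h; a higher number here means that more compound is tolerated, a lower number that less compound is tolerated:
compound 1, `CCCCNc1nc(N)nc2ccn(CC=C(C)C)c12`: > 24000 nM
compound 2, `CCCCNc1nc(N)nc2ccn(Cc3cn4ccccc4n3)c12`: > 24000 nM
compound 3, `CC(Nc1nc(N)nc2ccn(Cc3ccccn3)c12)c1ccccn1`: > 24000 nM

The result for compound 1 is a limit of the assay, not a number. The result for compound 2 is likewise a limit. Compound 3 also stands at a limit, so its place among the three cannot be fixed more closely than that. All three results share the same limit (the limit of > 24000 nM in this assay, at which 3 of the 3 values shown sit). No two measured compounds differ in one place only, so no step between measured compounds is counted, and the three structures cannot be ranked against one another on what is shown.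

Compound 4, `Cc1cc(CNc2nc(N)nc3ccn(Cc4ccccn4)c23)on1`, is the next member to be measured. It differs from compound 3 as follows: (3-methyl-1,2-oxazol-5-yl)methyl in place of 1-(pyridin-2-yl)ethyl on a nitrogen on an aromatic ring. For the measured compounds named here, nothing among the measured results separates one structure from another; every value sits at the same limit (the limit of > 24000 nM in this assay, at which 3 of the 3 values shown sit). The step expected is a step that the limit leaves unreadable from compound 3 to compound 4, none beyond the scatter, with compound 4 expected to remain at the limit as well. The estimate for compound 4 in this assay is 30000 nM, with a range from 15000 nM to 100000 nM.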

Compound 4, half-maximal cytotoxic concentration: > 24000 nM
Compound 4: a limit, no number; the forecaster's own chance of this, stated with the estimate: 85%; the middle value lies beyond the limit too.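

In this assay, compound 4 gives > 24000 nM, a limit of the assay and not a number, and compound 3 stands at a limit too, so no step between compound 3 and compound 4 can be read: the limit of > 24000 nM in this assay, at which 4 of the 4 values shown sit.

The compounds shown leave open whether 1-(pyridin-2-yl)ethyl and (3-methyl-1,2-oxazol-5-yl)methyl differ at all in this assay, and at what concentration, if any, cytotoxicity appears.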